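The source may report more compounds than this note shows. Statements on the series, on what has been measured and on what is new or still open speak of the compounds shown alone.

Among the compounds with values here, in a functional assay on MDA-MB-231 cells (Homo sapiens) for inhibition, read by MTT assay, with a stated time of 72 h (a lower number here means a stronger inhibitor, a higher number a weaker inhibitor), compound 2 `CC1=NN(c2ccccc2)C(=O)[C@@]12C(=O)C=CC[C@@H]2c1ccccc1[N+](=O)[O-]` gives 68300 nM, the highest of the three numbers so far. Its mirror image, compound 1 `CC1=NN(c2ccccc2)C(=O)[C@]12C(=O)C=CC[C@H]2c1ccccc1[N+](=O)[O-]`, gives 32400 nM, and compound 3 `CC1=NN(c2ccccc2)C(=O)[C@@]12C(=O)C=CC[C@H]2c1cccc(C)c1`, which carries no nitro, gives 6610 nM. Within the data shown here, the one measured step, a 2.1-fold higher number from compound 1 to compound 2 (0.32 log units; beyond the scatter), comes with the fact that compounds 1 and 2 differ only in the configuration as drawn, so it does not test the nitro. Compound 4 `CC1=NN(c2ccccc2)C(=O)[C@@]12C(=O)C=CC[C@@H]2c1ccccc1` differs from compound 2 by hydrogen in place of nitro on an aromatic carbon. Since compound 3 sits at 6610 nM without a nitro, though it differs elsewhere too, a moderately lower number is expected in this assay. The expected change is a 2.7-fold lower number from compound 2 to compound 4 (0.44 log units; beyond the scatter). For compound 4 the estimated value is 25000 nM, with an expected range of 8000 nM to 70000 nM.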

Compound 4, half-maximal inhibitory concentration: 9310 nM
Beside the measured number, compound 4's estimate is 2.7-fold (0.43 log units) above it; the range from low to high includes it.
By their numbers in this assay, from the lowest: compounds 3 and 4 (each within the scatter of the next); then compound 1; then compound 2.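

In this assay, going from 2-nitrophenyl to phenyl gives a 7.3-fold lower number from compound 2 to compound 4 (0.87 log units; beyond the scatter), a direct reading of what the nitro does at this place on the aromatic ring. In this drawn configuration, then, carrying the nitro goes with a weaker inhibitor. The only earlier step left the nitro untouched, as it rests on this: the fact that compounds 1 and 2 differ only in the configuration as drawn

As far as these compounds go, whether removing the nitro acts the same way in the mirror-image configuration remains open. So does how an amine or a carboxylic acid at this place would compare with hydrogen.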